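Series notes: aryl change from compound 3 to compound 4

The source may hold more compounds than are shown below. What is called first, only, known or untested is meant among the compounds shown, and "the series" means these compounds.

Three compounds have numbers in an assay on isolated protein for binding affinity to melanin-concentrating hormone receptor 1 (Homo sapiens); a higher number here means a weaker inhibitor, a lower number a stronger inhibitor. Compound 1 `CN(C(=O)N1CC[C@H](n2cnc3cc(-c4ccc(Cl)cc4)sc3c2=O)C1)[C@H]1CCN(C2CCC(C)(C)CC2)C1` gives 2 nM. Compound 2 `Cc1ccc(-c2cc3ncn([C@H]4CCN(C(=O)N(C)[C@H]5CCN(C)C5)C4)c(=O)c3s2)cc1` gives 15 nM, and compound 3 `Cc1ccc(-c2cc3ncn([C@H]4CCN(C(=O)N(C)[C@H]5CCN(C6CCOCC6)C5)C4)c(=O)c3s2)cc1` gives 14 nM. On these numbers compound 3 stands second highest of three: nearest is compound 2, whose value lies within the scatter of it, furthest is compound 1, whose value lies beyond the scatter. Among the compounds with values here, the only measured step, a 1.1-fold lower number from compound 2 to compound 3 (0.03 log units; within the scatter), alters the group on the amine nitrogen in a ring and leaves the aryl group untouched.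

Compound 4 `COc1ccc(-c2cc3ncn([C@H]4CCN(C(=O)N(C)[C@H]5CCN(C6CCOCC6)C5)C4)c(=O)c3s2)c(C)c1` differs from compound 3 by 4-methoxy-2-methylphenyl in place of 4-methylphenyl on an aromatic carbon. Within the data shown here, no measured step touches this aryl group. Compound 1 carries a different aryl group, but it also carries a different group on the amine nitrogen in a ring, so its value cannot be separated into a contribution of the aryl change. With nothing to carry over, the expectation for compound 4 is a step of no change at the digits printed from compound 3 to compound 4 (within the scatter), nothing beyond the scatter. Compound 4 is therefore estimated at 14 nM, with a range from 5 nM to 40 nM.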

Compound 4, inhibition constant: 28 nM
Compound 4: middle estimate off by 2.0-fold (0.30 log units), on the low side, within the range that was stated.
By their numbers in this assay, from the lowest: compound 1; then compounds 3, 2 and 4 (each within the scatter of the next).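

In this assay, within the data shown here, the first measured change at this aryl group, on an aromatic carbon next to the ring sulfur, gives a 2.0-fold higher number from compound 3 to compound 4 (0.30 log units; within the scatter) and so stays within the scatter. The position therefore tolerates 4-methoxy-2-methylphenyl, with 9 heavy atoms and a hydrogen-bond acceptor, in place of 4-methylphenyl, with 7 heavy atoms and none, and the two groups cannot be told apart on these numbers. The methyl and methoxy additions arrive together, so neither can be read alone, and no evidence at hand bears on this result.

Compound 1, at 2 nM, differs from compound 3 in two places, which leaves open how much of that gap belongs to its aryl group. Also open, on these data alone, is how this position responds to an aryl group carrying a carboxylic acid or an amine.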